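Swapping a sulfanyl arm for an aminopiperidine ring

A few compounds are considered here, and "the series" means these few. Any claim that something is new, unique, unknown or untested is made for them only; others in the source may bear on it.

Three compounds share one core and differ only in the group on one aromatic carbon of that core. Compound 1 `Cc1cc(C2CCC2)c(S(C)(=O)=O)cc1C(=O)N=C(N)N` carries a cyclobutyl there, compound 2 `Cc1cc(-c2ccco2)c(S(C)(=O)=O)cc1C(=O)N=C(N)N` a furan-2-yl, and compound 3 `Cc1cc(SC(C)(C)C)c(S(C)(=O)=O)cc1C(=O)N=C(N)N` a (tert-butyl)sulfanyl. In a functional assay for inhibition of sodium/hydrogen exchanger (Oryctolagus cuniculus) (a lower number here means a stronger inhibitor, a higher number a weaker inhibitor), compound 1 gives 8.2 nM, compound 2 gives 16 nM and compound 3 gives 22 nM. Compound 3 thus has the highest number of the three: the gap to compound 2 is small, a 1.4-fold higher number from compound 2 to compound 3 (0.14 log units; within the scatter), while the gap to compound 1 is somewhat larger, a 2.7-fold higher number from compound 1 to compound 3 (0.43 log units; beyond the scatter). Among the measured compounds shown here, the step of a 2.0-fold higher number from compound 1 to compound 2 (0.29 log units; within the scatter) is small as well, so every swap at this position so far moved the read-out only modestly.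

Compound 4 `Cc1cc(N2CCC(N)CC2)c(S(C)(=O)=O)cc1C(=O)N=C(N)N` is not yet measured. It differs from compound 3 in one place: 4-aminopiperidin-1-yl in place of (tert-butyl)sulfanyl on an aromatic carbon. The entering group brings a ring and a hydrogen-bond donor, a larger change than any of the three measured swaps, so the measured steps say only that this position accepts varied groups without large shifts. A step of modest size, in either direction, is therefore expected. For compound 4 a value near 25 nM is estimated in this assay, with a range from 7 nM to 90 nM, which corresponds to the expected step of a 1.1-fold higher number from compound 3 to compound 4 (0.06 log units; within the scatter).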

Compound 4, half-maximal inhibitory concentration: 9.8 nM
For compound 4 the middle estimate is 2.6-fold (0.41 log units) above the measured one, within the range that was stated.
By their numbers in this assay, from the lowest: compounds 1, 4, 2 and 3 (each within the scatter of the next, the first and the last beyond it).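

In this assay the 4-aminopiperidin-1-yl group, the only group of the four shown that holds a hydrogen-bond donor, gives a 2.2-fold lower number from compound 3 to compound 4 (0.35 log units; beyond the scatter), a modest step beyond the scatter, so the sulfanyl arm can give way to this larger ring with no loss at this aromatic carbon, ortho to a methylsulfonyl group. Measured against the other two groups, the same ring gives a 1.6-fold lower number from compound 2 to compound 4 (0.21 log units; within the scatter) and a 1.2-fold higher number from compound 1 to compound 4 (0.08 log units; within the scatter), both within the scatter, which places it level with furan-2-yl and cyclobutyl and shows that a saturated ring bonded through nitrogen and bearing an amine fits the range set by the earlier groups. No measurement offered here explains why the number shifts from compound 3 to compound 4.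

Still open, from the compounds shown here alone, is whether the amino group on the ring matters at all, or whether the ring alone would do, a question that a plain piperidin-1-yl group or a morpholine ring could answer. Equally open, going by these compounds, is how a carboxylic acid or a longer amine chain at this same carbon would compare with compound 4 .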